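Swapping the Aryl Group on the Triazole Nitrogen

A few compounds are considered here, and "the series" means these few. Any claim that something is new, unique, unknown or untested is made for them only; others in the source may bear on it.

Measured so far:
compound 1, `Cc1cccc(-n2cc(-c3ccc(NS(=O)(=O)c4c[nH]c(=O)[nH]c4=O)cc3)nn2)c1`: 6960 nM
compound 2, `O=c1[nH]cc(S(=O)(=O)Nc2ccc(-c3cn(-c4ccc(F)cc4)nn3)cc2)c(=O)[nH]1`: 9720 nM

Both compounds were tested in a functional assay on A549 cells (Homo sapiens) for antiproliferative activity, read by MTT assay, with a stated time of 24 h; a lower number here means a stronger inhibitor, a higher number a weaker inhibitor. Compound 1 gives 6960 nM and compound 2 gives 9720 nM. Within the data shown here, the only structural step recorded between them, a 1.4-fold higher number from compound 1 to compound 2 (0.15 log units; within the scatter), falls within the scatter, so the two compounds cannot be told apart on these numbers; compound 2 simply sits alongside compound 1.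

Compound 3, `O=c1[nH]cc(S(=O)(=O)Nc2ccc(-c3cn(-c4ccccc4Cl)nn3)cc2)c(=O)[nH]1`, has not yet been measured. It differs from compound 2 in one place: 2-chlorophenyl in place of 4-fluorophenyl on an aromatic nitrogen. Among the measured compounds shown here, the one recorded step that bears on this kind of change is the exchange of the aryl group on the same nitrogen, a 1.4-fold higher number from compound 1 to compound 2 (0.15 log units; within the scatter), and it was within the scatter. For the measured compounds named here, no step with a 2-chlorophenyl group exists in these data, so there is nothing to suggest a larger move. The expected step from compound 2 to compound 3 in this assay is therefore a 1.1-fold lower number from compound 2 to compound 3 (0.06 log units; within the scatter), essentially no change beyond the scatter. Compound 3 is estimated at 8500 nM, with a plausible range from 3000 nM to 25000 nM.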

Compound 3, half-maximal inhibitory concentration: 2810 nM
The estimate for compound 3 lay 3.0-fold (0.48 log units) above the measured number; the measured number lies below the stated range.
By their numbers in this assay, from the lowest: compound 3; then compounds 1 and 2 (each within the scatter of the next).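

In this assay, the aryl group on this aromatic nitrogen now shows a readable effect, which the first two compounds could not show: replacing 4-fluorophenyl with 2-chlorophenyl gives a 3.5-fold lower number from compound 2 to compound 3 (0.54 log units; beyond the scatter) and sets compound 3 clearly apart from compound 2. Compound 3 also stands apart from the 3-methylphenyl compound, with a 2.5-fold lower number from compound 1 to compound 3 (0.39 log units; beyond the scatter), so the change holds against both earlier aryl groups, although both steps are modest and the groups exchanged have the same count of heavy atoms and the same single carbon ring. Nothing available here offers an explanation for this gain in antiproliferative activity.

The step from compound 2 to compound 3 changes both the halogen and its location on the phenyl ring, so the compounds shown cannot say which of the two matters, or whether chlorine is needed at all. As far as these compounds go, it also remains open how this position would respond to a plain phenyl, a methoxy group or an amine on the ring, or to a saturated group such as cyclohexyl in place of the aryl ring.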